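A Hydroxy for an Amino on an Inactive Starting Point

The source may hold more compounds than are shown below. What is called first, only, known or untested is meant among the compounds shown, and "the series" means these compounds.

Three measured compounds set the scene. Compound 1, `CCn1nnc(-c2sc(-c3cccc(OC)c3)nc2O)n1`, gives 245 nM in an assay on HEK293 cells for inhibition of transient receptor potential cation channel subfamily M member 8 (Homo sapiens), read by FLIPR, with stated times of 5 min and 3 min; on this read-out lower numbers stand for stronger inhibition and higher numbers for weaker inhibition. Compound 3, `CSc1cc(-c2ccc(Cl)cc2)[nH]n1`, gives 977 nM in this assay. Compound 2, `CCOC(=O)c1sc(-c2ccccc2)nc1N`, stands apart from both: in this assay compound 2 yields only > 100000 nM, which is a limit of the assay and not a measured number. Among the three values shown, compound 2 alone sits at that limit, as the limit of > 100000 nM in this assay, at which 1 of the 3 values shown sits, records; compounds 1 and 3 both return actual numbers.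

The step under consideration leads from compound 2 to compound 4, `CCOC(=O)c1sc(-c2ccccc2)nc1O`, which has not yet been measured. The change is hydroxy in place of amino on an aromatic carbon. Nothing else moves: the ethoxycarbonyl group and the group of 6 heavy atoms stay in place on the shared core.

Going by the values given here, no measured pair differing in one place is available to calibrate this change, so the size of the step in this assay is uncertain. Since compound 2 gives only a limit, any real number for compound 4 would register as a gain, and a result that again falls at the limit cannot be excluded. Compound 4 is expected to give about 50000 nM, within a range from 5000 nM to 100000 nM, corresponding to an expected step of an at least 2.0-fold lower number from compound 2 to compound 4 (0.30 log units; that floor lies within the scatter).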

Compound 4, half-maximal inhibitory concentration: 32 nM
The estimate for compound 4 lay 1600-fold (3.19 log units) above the measured number; the whole stated range lies above it.
By their numbers in this assay, from the lowest: compound 4; then compound 1; then compound 3. At a limit, above all of these: compound 2.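

In this assay, hydroxy in place of amino on this aromatic carbon, next to the ring nitrogen and next to the ring atom that bears an ethoxycarbonyl group, gives an at least 3100-fold lower number from compound 2 to compound 4 (3.49 log units; beyond the scatter), so this one position decides between a real number and none on the shared core. Compound 2 stands at a limit of the assay and not at a number, which makes the printed size of the step a floor: the limit of > 100000 nM in this assay, at which 1 of the 4 values shown sits. The two groups match in heavy atom count, in hydrogen-bond donors and acceptors and in net charge, so none of these counts separates them, and what the step records is a single oxygen standing for a single nitrogen at this place.

As far as these compounds go, it remains open whether a methoxy group or a fluorine on the same carbon would hold the number of compound 4, 32 nM, or whether it takes the hydroxy itself. From the compounds shown here alone, it is equally open whether the hydroxy would keep this effect with a carboxylic acid or an amide in place of the ethoxycarbonyl group.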